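Aryl substituent swap in a tricyclic corticotropin-releasing factor series

The source may report more compounds than this note shows. Statements on the series, on what has been measured and on what is new or still open speak of the compounds shown alone.

Measured compounds:
Compound 1 `CCCCN(CC)c1cc(C)nc2c1NC(=O)CN2c1ccc(C(C)(C)C)cc1Br` gives 4.2 nM in an assay on HEK-293T cells for displacement of a labelled ligand from corticotropin-releasing factor receptor 1 (Homo sapiens), read by scintillation counting, with a stated time of 2 h; on this read-out lower numbers stand for stronger inhibition and higher numbers for weaker inhibition.
Compound 2 `CCCCN(CC)c1cc(C)nc2c1NC(=O)CN2c1ccc(C(C)C)cc1Br` gives 2.4 nM in this assay.
Compound 3 `CCCCN(CC)c1cc(C)nc2c1NC(=O)CN2c1ccc(Br)cc1Br` gives 1.3 nM in this assay.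

Among the measured compounds shown here, compound 3 holds the lowest number of the three, but only the step from compound 1 is beyond the scatter (a 3.2-fold lower number from compound 1 to compound 3 (0.51 log units; beyond the scatter)); compound 2 sits within the scatter of compound 3 (a 1.8-fold lower number from compound 2 to compound 3 (0.27 log units; within the scatter)), so no order between those two can be read. The step of a 1.8-fold lower number from compound 1 to compound 2 (0.24 log units; within the scatter) is likewise within the scatter.

Compound 4 `CCCCN(CC)c1cc(C)nc2c1NC(=O)CN2c1ccc(Br)cc1C` is not yet measured. It differs from compound 3 as follows: methyl in place of bromo on an aromatic carbon. For the measured compounds named here, no measured pair trades bromo for methyl at this position. The two steps that bear on it are a 3.2-fold lower number from compound 1 to compound 3 (0.51 log units; beyond the scatter) and a 1.8-fold lower number from compound 2 to compound 3 (0.27 log units; within the scatter), both of which put bromo in place of an alkyl group and both of which lowered the number, one modestly and one within the scatter. Reversing that direction with the smallest alkyl group suggests a small rise in the number for compound 4, expected near a 1.9-fold higher number from compound 3 to compound 4 (0.28 log units; within the scatter), most likely within the scatter. Compound 4 is therefore estimated at 2.5 nM, with a range of 1 nM to 6 nM.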

Compound 4, inhibition constant: 4.4 nM
The estimate for compound 4 lay 1.8-fold (0.25 log units) below the measured number; low and high end bracket the measured number.
By their numbers in this assay, from the lowest: compounds 3, 2, 1 and 4 (each within the scatter of the next, the first and the last beyond it).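

In this assay the change from 2,4-dibromophenyl to 4-bromo-2-methylphenyl gives a 3.4-fold higher number from compound 3 to compound 4 (0.53 log units; beyond the scatter) and shows that bromo and methyl are not interchangeable on this aromatic carbon, ortho to a large group. Among the compounds shown here, the earlier compounds all kept bromo here and differed only in the other aryl substituent, so this is the first reading of this position, and a swap of one heavy atom for one heavy atom is enough to move the number beyond the scatter. No measurement shown gives a reason for this step.

Going by these compounds, whether chloro, methoxy or plain hydrogen at this position would track bromo or methyl remains open. So does whether the same change carries over when isopropyl or tert-butyl replaces the other bromo.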